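A few compounds are considered here, and "the series" means these few. Any claim that something is new, unique, unknown or untested is made for them only; others in the source may bear on it.

Measured so far:
- compound 1 `COc1cc2ncnc(Nc3cccc(F)c3)c2cc1OCCCCC(=O)Nc1ccc(S(N)(=O)=O)cc1`: > 40000 nM
- compound 2 `COc1cc2ncnc(Nc3cccc(Cl)c3F)c2cc1OCCCCC(=O)Nc1ccc(S(N)(=O)=O)cc1`: 10500 nM
- compound 3 `NS(=O)(=O)c1ccc(NC(=S)Nc2ccc3ncnc(Nc4cccc(Cl)c4F)c3c2)cc1`: > 40000 nM

All three were tested in a functional assay on A549 cells (Homo sapiens) for antiproliferative activity, read by MTT assay, with a stated time of 72 h; on this read-out lower numbers stand for stronger inhibition and higher numbers for weaker inhibition. Compound 2 gives 10500 nM. For compound 1 the value > 40000 nM is a limit of the assay rather than a number. For compound 3 the value > 40000 nM is likewise a limit. For the measured compounds named here, the one step that can be sized runs an at least 3.8-fold higher number from compound 2 to compound 1 (0.58 log units; beyond the scatter), and the change behind it is 3-fluorophenyl in place of 3-chloro-2-fluorophenyl on a nitrogen on an aromatic ring. How the core of compound 2 differs from the core of compound 3 is not broken down here.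

Compound 4 `NS(=O)(=O)c1ccc(NC(=S)Nc2ccc3ncnc(Nc4cccc(F)c4)c3c2)cc1` has not been measured. It differs from compound 3 by 3-fluorophenyl in place of 3-chloro-2-fluorophenyl on a nitrogen on an aromatic ring, the same change at the same place as between compound 2 and compound 1. In that measured pair the number rose by an at least 3.8-fold higher number from compound 2 to compound 1 (0.58 log units; beyond the scatter), and compound 3 already sits at the limit of > 40000 nM in this assay, at which 2 of the 3 values shown sit, so the same change is expected to leave compound 4 at or beyond that limit, a step that the limit leaves unreadable from compound 3 to compound 4. Compound 4 is therefore estimated at 70000 nM, with a range from 30000 nM to 200000 nM.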

Compound 4, half-maximal inhibitory concentration: 25900 nM
Beside the measured number, compound 4's estimate is 2.7-fold (0.43 log units) above it; the whole stated range lies above it.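

In this assay, the change from 3-chloro-2-fluorophenyl to 3-fluorophenyl does not carry over from one core to the other with the same effect, as the two steps differ clearly: the same change on two cores in this assay, an at least 3.8-fold higher number (0.58 log units; beyond the scatter) from compound 2 to compound 1 and an at least 1.5-fold lower number (0.18 log units; that floor lies within the scatter) from compound 3 to compound 4, at least 5.8-fold (0.76 log units) apart, beyond the scatter of two such steps Compound 3 gives > 40000 nM, which is a limit of the assay and not a number. The new step, an at least 1.5-fold lower number from compound 3 to compound 4 (0.18 log units; that floor lies within the scatter), is thus only a floor, so the data show that the result on one core cannot simply be transferred to the other, but they do not show the true size of either step or why the two cores part ways.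

Going by these compounds, it remains open whether the same change would behave in the same way on a close relative of compound 3 with a urea in place of its thiourea. Also open, on these data alone, is how the aromatic ring on the nitrogen would fare on either core with a methoxy or an ethynyl group in place of the halogens.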